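Changing the group on the nitrogen of compound 3

This account rests on a few compounds, and the source may have more. Where it says the series, first, only, none or still open, it means among the compounds named here.

Measured so far in a functional assay on K562 cells (Homo sapiens) for inhibition, read by trypan blue exclusion, with a stated time of 72 h; a higher number here means a weaker inhibitor, a lower number a stronger inhibitor
- compound 1 `COc1ccc(Nc2ncc3cc(S(=O)(=O)c4ccc(C)cc4)c(=O)n(C)c3n2)cc1` gives 75000 nM
- compound 2 `Cc1ccc(S(=O)(=O)c2cc3cnc(Nc4cnc5c(c4)CC(=O)N5)nc3n(C)c2=O)cc1` gives 15000 nM
- compound 3 `Cc1ccc(S(=O)(=O)c2cc3cnc(Nc4cnc5[nH]ccc5c4)nc3n(C)c2=O)cc1` gives 15000 nM

Compound 3 shares the lowest number with compound 2, and compound 1 stands apart. Compound 4 `Cc1ccc(S(=O)(=O)c2cc3cnc(Nc4cccc5cccnc45)nc3n(C)c2=O)cc1` brings in quinolin-8-yl, and the change is a group of 10 heavy atoms (9 carbon, 1 nitrogen; one six-membered aromatic ring of carbon only, one six-membered aromatic ring with 1 hetero atom) in place of a group of 9 heavy atoms (7 carbon, 2 nitrogen; one five-membered aromatic ring with 1 hetero atom, one six-membered aromatic ring with 1 hetero atom), on a nitrogen on an aromatic ring within the same core. Three measured steps changed this same group. Two were modest (a 5.0-fold lower number from compound 1 to compound 2 (0.70 log units; beyond the scatter) and a 5.0-fold lower number from compound 1 to compound 3 (0.70 log units; beyond the scatter)) and one showed nothing (no change at the digits printed from compound 2 to compound 3 (within the scatter)). No change beyond the scatter is therefore expected in this assay for this new group. The estimate amounts to an expected 1.3-fold higher number from compound 3 to compound 4 (0.12 log units; within the scatter) (within the scatter). Compound 4 is estimated at 20000 nM (expected range 7000 nM to 60000 nM).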

Compound 4, half-maximal inhibitory concentration: 10000 nM
Compound 4: the middle estimate sits 2.0-fold (0.30 log units) above what was measured; the measured number falls inside the stated range.
By their numbers in this assay, from the lowest: compounds 4, 2 and 3 (each within the scatter of the next); then compound 1.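

In this assay, quinolin-8-yl carries no hydrogen-bond donor, whereas the group it replaces in compound 3 carries one, yet both steps stay within the scatter: a 1.5-fold lower number from compound 3 to compound 4 (0.18 log units; within the scatter) and a 1.5-fold lower number from compound 2 to compound 4 (0.18 log units; within the scatter). Among the compounds shown here, only the step from 4-methoxyphenyl goes beyond the scatter, a 7.5-fold lower number from compound 1 to compound 4 (0.88 log units; beyond the scatter), so compound 1 remains apart from compounds 2, 3 and 4. No evidence is available to explain these numbers. From the compounds shown here alone, whether a phenyl group carrying an amine or a carboxylic acid on this nitrogen would give a number outside this cluster remains open.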